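Thiophen-3-yl replacing 5-chlorothiophen-2-yl on compound 1

The compounds below may be only part of what the source reports. "The series", "measured", "known", "first", "only" and "open" are said of these compounds alone.

Within the data shown here, in an ADME assay on Vero cells (Chlorocebus sabaeus) for cytotoxicity, read by MTT assay, with a stated time of 96 h (a higher number here means that more compound is tolerated, a lower number that less compound is tolerated), compound 1 (`COc1cc(NCc2ccc(Cl)s2)ccc1-c1cnco1`) gives 53800 nM as the lowest of the three numbers measured so far. Compound 2 (`COc1cc(/N=C/c2ccc(F)cc2)ccc1-c1cnco1`) gives 325000 nM and compound 3 (`COc1cc(/N=C/c2ccncc2)ccc1-c1cnco1`) gives 239000 nM and both stand beyond the scatter from compound 1.

Compound 4 (`COc1cc(NCc2ccsc2)ccc1-c1cnco1`) carries thiophen-3-yl in place of 5-chlorothiophen-2-yl on a saturated chain carbon bound to a nitrogen on an aromatic ring. Among the measured compounds shown here, no measured step covers this change. The nearest evidence is a 1.4-fold lower number from compound 2 to compound 3 (0.13 log units; within the scatter) which lies within the scatter, but that exchange sits on a carbon with a double bond to nitrogen, so it bears on the change only indirectly.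

The expected step is a 1.7-fold higher number from compound 1 to compound 4 (0.22 log units; within the scatter) in this assay and it is estimated to stay within the scatter, leaning towards a higher number. That lean rests only on a single comparison, in which compound 1 gives 53800 nM and compound 3 gives 239000 nM. For compound 4 the estimate is 90000 nM with an expected range from 35000 nM to 230000 nM still to be tested by measurement.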

Compound 4, half-maximal cytotoxic concentration: 181000 nM
For compound 4 the middle estimate is 2.0-fold (0.30 log units) below the measured one; the range from low to high includes it.
By their numbers in this assay, from the lowest: compound 1; then compounds 4, 3 and 2 (each within the scatter of the next).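

In this assay, thiophen-3-yl in place of 5-chlorothiophen-2-yl on a saturated chain carbon bound to a nitrogen on an aromatic ring gives a 3.4-fold higher number from compound 1 to compound 4 (0.53 log units; beyond the scatter) and so shows that a change at this position can exceed the scatter. The earlier exchange, on a carbon with a double bond to nitrogen, gave a 1.4-fold lower number from compound 2 to compound 3 (0.13 log units; within the scatter) and stayed within it. No measurement on hand accounts for the new step.

The step combines the loss of chlorine with a change from thiophen-2-yl to thiophen-3-yl, and the compounds shown do not separate the two; unsubstituted thiophen-2-yl on the same carbon would do so. Also open, going by these compounds, is how this assay responds when an amine or a longer chain replaces (thiophen-3-yl)methyl.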